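The source may hold more compounds than are shown below. What is called first, only, known or untested is meant among the compounds shown, and "the series" means these compounds.

Measured compounds:

compound 1, `CCCCCCC(Sc1nc(Cl)cc(Oc2ccc3ncccc3c2)n1)C(=O)O`, 91.4%
compound 2, `CCCCC(Sc1nc(Cl)cc(Nc2ccc3ncccc3c2)n1)C(=O)OCC`, 51.8%
compound 3, `CCOC(=O)CSc1nc(Cl)cc(OCc2ccc3ncccc3c2)n1`, 80%

All three were tested in an assay for inhibition of Polyunsaturated fatty acid 5-lipoxygenase (Homo sapiens), tested at 1 uM; on this read-out lower numbers stand for a stronger effect and higher numbers for a weaker effect at the one concentration tested. Compound 2 gives the lowest number of the three in this assay; its gap to compound 3 and its gap to compound 1 both lie beyond the usual scatter of this kind of measurement, so on these numbers compound 2 shows the strongest effect of the three.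

The step goes from compound 2 to compound 4, `CCOC(=O)C(Sc1nc(Cl)cc(Nc2ccc3ncccc3c2)n1)c1ccccc1`, which has not yet been measured. The change is phenyl in place of butyl on a saturated chain carbon bound to a carbonyl carbon and a sulfur. Among the measured compounds shown here, no pair of measured compounds differs in exactly one place, so there is no measured step to lean on here: the only guide is the number that compound 2 itself gives in this assay, 51.8%.

With nothing shown for this kind of change, a modest step in either direction, or none beyond the scatter, seems the fair expectation: the step is estimated as a number 1.8 percentage points lower from compound 2 to compound 4 (within the scatter). For compound 4 in this assay the expected value is 50%, within a range from 25% to 78%.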

Compound 4, a percentage reported as activity, at one concentration (the size of the read-out at that concentration, not a potency): 52.7%
Beside the measured number, compound 4's estimate is 2.7 percentage points below it; the measured number falls inside the stated range.
By their numbers in this assay, from the lowest: compounds 2 and 4 (each within the scatter of the next); then compound 3; then compound 1.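

In this assay, among the compounds shown here, the only measured step that changes a single place puts phenyl in place of butyl on a saturated chain carbon bound to a carbonyl carbon and a sulfur, and it gives a number 0.9 percentage points higher from compound 2 to compound 4 (within the scatter). An open chain of carbons and a six-membered aromatic ring of carbon therefore cannot be told apart at this position on this read-out, despite the difference in their shape and size. Nothing on hand explains why the two groups read alike.

Still open, as far as these compounds go, is whether other groups at this position, such as cyclohexyl, benzyl or a simple methyl, would also stay within the scatter of these two. From the compounds shown here alone, it is also open whether a substituent on the phenyl ring, such as a methoxy group or a chlorine, would move the number in either direction.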